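Working notes: thiophen-2-yl to phenyl on a carbonyl carbon

A few compounds are considered here, and "the series" means these few. Any claim that something is new, unique, unknown or untested is made for them only; others in the source may bear on it.

Measured so far in an ADME assay on HepG2 2.2.15 cells (Homo sapiens) for cytotoxicity, read by MTT assay (a higher number here means that more compound is tolerated, a lower number that less compound is tolerated), with three compounds
Compound 1 `C=C1CC[C@@H]2[C@](C)(COC(=O)/C=C/c3ccccc3)[C@H](O)CC[C@@]2(C)[C@@H]1C/C=C1\C=COC1=O` gives 271000 nM
Compound 2 `C=C1CC[C@@H]2[C@](C)(COC(=O)c3cccnc3)[C@H](O)CC[C@@]2(C)[C@@H]1C/C=C1\C=COC1=O` gives 2050000 nM
Compound 3 `C=C1CC[C@@H]2[C@](C)(COC(=O)c3cccs3)[C@H](O)CC[C@@]2(C)[C@@H]1C/C=C1\C=COC1=O` gives 2470000 nM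

Compound 3 and compound 2 lie within the scatter of each other, and both stand beyond the scatter above compound 1. Compound 4 `C=C1CC[C@@H]2[C@](C)(COC(=O)c3ccccc3)[C@H](O)CC[C@@]2(C)[C@@H]1C/C=C1\C=COC1=O` differs from compound 3 by phenyl in place of thiophen-2-yl on a carbonyl carbon and so carries phenyl in place of thiophen-2-yl on a carbonyl carbon.

Among the compounds with values here, the nearest precedent is an exchange of one ring group for another at this place, a 1.2-fold higher number from compound 2 to compound 3 (0.08 log units; within the scatter) and thus no real change. The steps away from 2-phenylethenyl are larger, a 7.6-fold higher number from compound 1 to compound 2 (0.88 log units; beyond the scatter) and a 9.1-fold higher number from compound 1 to compound 3 (0.96 log units; beyond the scatter) in modest measure, but compound 3 and compound 4 both lack that group. Within the data shown here, compound 1 with 271000 nM is the only measured compound holding a phenyl group, which gives the expectation a slight lean to a lower number.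

No step beyond the scatter is expected in this assay for this change. The estimated step is a 1.5-fold lower number from compound 3 to compound 4 (0.16 log units; within the scatter) as expected here. For compound 4 the estimate is 1700000 nM with an expected range of 600000 nM to 3200000 nM for the coming measurement.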

Compound 4, half-maximal cytotoxic concentration: 82000 nM
Compound 4: middle estimate off by 21-fold (1.32 log units), on the high side; the whole stated range lies above it.
By their numbers in this assay, from the lowest: compound 4; then compound 1; then compounds 2 and 3 (each within the scatter of the next).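

In this assay the group on this carbonyl carbon proves far from interchangeable among rings: a 30-fold lower number from compound 3 to compound 4 (1.48 log units; beyond the scatter) and a 25-fold lower number from compound 2 to compound 4 (1.40 log units; beyond the scatter) stand against the earlier exchange of pyridin-3-yl for thiophen-2-yl, which stayed within the scatter. With a 3.3-fold lower number from compound 1 to compound 4 (0.52 log units; beyond the scatter) as well, benzoyl and not the 2-phenylethenyl ester gives the lowest number of the four, so the two compounds whose ring holds only carbon, compound 1 and compound 4, lie below the two whose ring holds a hetero atom, compound 2 and compound 3, with none going against this. Nothing measured on this series accounts for the gap.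

From the compounds shown here alone, whether the hetero atom itself decides the number remains open. A phenyl ring carrying an amine or a carboxylic acid, or a saturated cyclohexyl group on the same carbonyl carbon, would bear on that.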